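Same atoms, shifted between ring and chain

The source may hold more compounds than are shown below. What is called first, only, known or untested is meant among the compounds shown, and "the series" means these compounds.

Of the compounds shown here, three built on one shared core have been measured in a functional assay on HepG2 cells (Homo sapiens) for antiproliferative activity, read by MTT assay, with a stated time of 48 h; on this read-out higher numbers stand for weaker inhibition and lower numbers for stronger inhibition. Compound 1, `COc1cc2oc(-c3ccccc3)cc(=O)c2c(O)c1OCCCN1CCCCC1`, gives 22300 nM. Compound 2, `O=c1cc(-c2ccccc2)oc2cc(OCc3ccccc3)c(OCCCN3CCCC3)c(O)c12`, gives 4200 nM, and compound 3, `CN1CCN(CCCCOc2c(O)cc3oc(-c4ccccc4)cc(=O)c3c2O)CC1`, gives 93700 nM. Among these three numbers compound 1 stands second highest: compound 3 is separated from it by a larger number and compound 2 by a smaller one, and both gaps lie beyond the usual scatter of this assay.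

The next compound, compound 4, `COc1cc2oc(-c3ccccc3)cc(=O)c2c(O)c1OCCCCN1CCCC1`, has the same atoms as compound 1 joined differently: (pyrrolidin-1-yl)methyl in place of piperidin-1-yl on a saturated chain carbon, three bonds along the chain from an oxygen on an aromatic ring. Cut one bond further out, the same difference reads 3-(piperidin-1-yl)propyl to 4-(pyrrolidin-1-yl)butyl, so one ring member moves into the chain.

Within the data shown here, no measured pair isolates this change. Compound 2 also carries a pyrrolidin-1-yl group, yet it differs from compound 1 elsewhere as well, and compound 3 differs in several places too, so neither value anchors the step. Without such an anchor, the step of a 1.1-fold lower number from compound 1 to compound 4 (0.05 log units; within the scatter) is expected to stay within the scatter, with no clear direction. Compound 4 is therefore estimated at 20000 nM, with a range from 8000 nM to 50000 nM.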

Compound 4, half-maximal inhibitory concentration: 4900 nM
Beside the measured number, compound 4's estimate is 4.1-fold (0.61 log units) above it; measured number below the stated range.
By their numbers in this assay, from the lowest: compounds 2 and 4 (each within the scatter of the next); then compound 1; then compound 3.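

Among these compounds, although the atoms stay the same, this assay records a 4.6-fold lower number from compound 1 to compound 4 (0.66 log units; beyond the scatter) and so gives the first direct reading of a single change. At this position, on a saturated chain carbon three bonds along the chain from an oxygen on an aromatic ring, the number therefore depends on how the atoms are joined and not only on which atoms are present. The pair links the lower number to 4-(pyrrolidin-1-yl)butyl and the higher one to 3-(piperidin-1-yl)propyl, but no accompanying measurement bears on why the two differ.

This single step changes ring size and chain length together, so it cannot show which of the two carries the difference; on the core of compound 1, a 3-(pyrrolidin-1-yl)propyl chain and a 4-(piperidin-1-yl)butyl chain would pull these two changes apart. Also open, on these data alone, is whether the trend continues with a longer chain such as 5-(pyrrolidin-1-yl)pentyl, or what happens when a morpholin-4-yl ring takes the place of the pyrrolidine.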